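A Second Trifluoromethyl on the Z Alkene Compound

The source may hold more compounds than are shown below. What is called first, only, known or untested is meant among the compounds shown, and "the series" means these compounds.

Measured compounds, with values from a functional assay on MDA-MB-468 cells (Homo sapiens) for antiproliferative activity, read by sulforhodamine B assay, with a stated time of 72 h; on this read-out higher numbers stand for weaker inhibition and lower numbers for stronger inhibition:
- compound 1 `COc1ccc2nc(Cl)c(/C=C\c3ccc(C(F)(F)F)cc3)cc2c1` gives 22700 nM
- compound 2 `FC(F)(F)c1cccc(/C=C\c2cc3ccccc3nc2Cl)c1` gives 3700 nM
- compound 3 `FC(F)(F)c1cccc(/C=C/c2cc3ccccc3nc2Cl)c1` gives 24000 nM

Compound 2 gives the lowest number of the three, and compound 1 and compound 3 both lie above it by more than the usual scatter. The next compound, compound 4 `FC(F)(F)c1cc(/C=C\c2cc3ccccc3nc2Cl)cc(C(F)(F)F)c1`, has not yet been measured. It carries trifluoromethyl in place of hydrogen on an aromatic carbon of compound 2, and the counted difference is trifluoromethyl in place of hydrogen on an aromatic carbon. Going by the values given here, only one measured step links two compounds that differ in a single place, namely a 6.5-fold higher number from compound 2 to compound 3 (0.81 log units; beyond the scatter). That step lies beyond the scatter and is traced to the fact that compounds 2 and 3 differ only in the configuration as drawn, so it bears on the new group only indirectly. Among the compounds with values here, it shows how far the numbers can move in this small set, but no measured step adds a substituent. Compound 1 differs from compound 2 in more than one place, so compound 1 at 22700 nM offers no clean comparison either. With so little to go on, only a small change leaning toward a higher number is expected, most likely within the scatter. The expected change is a 1.6-fold higher number from compound 2 to compound 4 (0.21 log units; within the scatter) and this remains an uncertain estimate. In this assay compound 4 is estimated at 6000 nM, with an expected range from 1500 nM to 22000 nM.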

Compound 4, half-maximal inhibitory concentration: 10500 nM
Compound 4: the middle estimate sits 1.8-fold (0.24 log units) below what was measured, within the range that was stated.
By their numbers in this assay, from the lowest: compound 2; then compound 4; then compounds 1 and 3 (each within the scatter of the next).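

In this assay, trifluoromethyl in place of hydrogen on an aromatic carbon, meta to a large group and meta to a trifluoromethyl group, gives a 2.8-fold higher number from compound 2 to compound 4 (0.45 log units; beyond the scatter), so this position is not indifferent to the change: the first added substituent in the set moves the number beyond the scatter, toward weaker inhibition. Together with a 6.5-fold higher number from compound 2 to compound 3 (0.81 log units; beyond the scatter), this means that both measured single changes away from compound 2 give a higher number, one by adding a group to the aromatic ring and the other by changing only the configuration of the double bond. Nothing given here accounts for the cost of the added trifluoromethyl.

As far as these compounds go, what stays open is whether this position responds in the same direction to other groups, such as an amine, a nitrile or a carboxylic acid, since a single substituent cannot show a trend at this carbon. From the compounds shown here alone, it is also open whether a second trifluoromethyl would shift the number in the same way on the E alkene of compound 3.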